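The source may hold more compounds than are shown below. What is called first, only, known or untested is meant among the compounds shown, and "the series" means these compounds.

Values in a functional assay (trachea) with Cavia porcellus as the target; a higher number here means a weaker inhibitor, a lower number a stronger inhibitor:
compound 1 `Oc1nnc(-c2cccnc2)c2ccccc12`: 10200 nM
compound 2 `CC(C)n1nc(-c2cccnc2)c2ccccc2c1=O`: 3090 nM
compound 3 `CCCCn1nc(-c2cccnc2)c2ccccc2c1=O`: 2290 nM

In this assay compound 3 gives 2290 nM, a clearly lower number than compound 1, which gives 10200 nM. Compound 3 cannot be separated from compound 2, however, as the measured step is a 1.3-fold lower number from compound 2 to compound 3 (0.13 log units; within the scatter).

Compound 4 `O=c1c2ccccc2c(-c2cccnc2)nn1C1CCCC1` has not yet been measured. It carries cyclopentyl in place of butyl on an aromatic nitrogen of the shared core: cyclopentyl in place of butyl on an aromatic nitrogen.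

Within the data shown here, only one measured step bears on this change, the exchange of isopropyl for butyl on that same nitrogen. It is a 1.3-fold lower number from compound 2 to compound 3 (0.13 log units; within the scatter), so swapping one of these groups for the other left the number within the scatter. On that evidence, no step beyond the scatter is expected in this assay, and no direction can be favoured. Among the measured compounds shown here, this is thin support, since it rests on a single step and no compound with a ring at this place has been measured, so the range is kept wide.

The expected step is a 1.0-fold higher number from compound 3 to compound 4 (0.02 log units; within the scatter).

For compound 4 the estimated value is 2400 nM, with an expected range from 1000 nM to 5500 nM.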

Compound 4, half-maximal inhibitory concentration: 2750 nM
Compound 4: the middle estimate sits 1.1-fold (0.06 log units) below what was measured; low and high end bracket the measured number.
By their numbers in this assay, from the lowest: compounds 3, 4 and 2 (each within the scatter of the next); then compound 1.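

In this assay the step of a 1.2-fold higher number from compound 3 to compound 4 (0.08 log units; within the scatter) and the step of a 1.1-fold lower number from compound 2 to compound 4 (0.05 log units; within the scatter) place cyclopentyl, the first ring seen on this aromatic nitrogen, level with both open-chain groups. Compounds 2, 3 and 4 therefore cannot be separated, and on this nitrogen the exchange of butyl or isopropyl for a five-membered non-aromatic ring of carbon only does not produce a step beyond the scatter. The data available here offer no measurement that would account for this result.

The compounds shown leave open whether a phenyl or benzyl group, a longer chain, or a chain ending in an amine or a carboxylic acid on this same nitrogen would produce a step beyond the scatter. They also leave open whether the flat response among these three compounds would persist if the pyridin-3-yl group were exchanged for another group, such as phenyl.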